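A few compounds are considered here, and "the series" means these few. Any claim that something is new, unique, unknown or untested is made for them only; others in the source may bear on it.

Measured in a functional assay (plasma) for inhibition, with Homo sapiens as the target (a lower number here means a stronger inhibitor, a higher number a weaker inhibitor), so far:
Compound 1 `O=C(O)CCC/C=C\C[C@H]1/C(=N/OCc2ccc(C(F)(F)F)cc2)CC[C@@H]1NS(=O)(=O)c1ccc(Cl)cc1` gives 200 nM
Compound 2 `O=C(O)CC/C=C\C[C@@H]1[C@@H](NS(=O)(=O)c2ccc(F)cc2)CC[C@@H]1O` gives 1600 nM
Compound 3 `O=C(O)CCC/C=C\C[C@H]1/C(=N/OCC2CCCCC2)CC[C@@H]1NS(=O)(=O)c1ccc(Cl)cc1` gives 1700 nM

Compound 1 holds the lowest of the three numbers, with compound 2 and compound 3 both higher beyond the scatter. Compound 4 `O=C(O)CCC/C=C\C[C@H]1/C(=N/OCc2ccc(C(F)(F)F)cc2)CC[C@@H]1NS(=O)(=O)c1ccc(F)cc1` changes compound 1 in one place, fluoro in place of chloro on an aromatic carbon. For the measured compounds named here, the only measured step, an 8.5-fold higher number from compound 1 to compound 3 (0.93 log units; beyond the scatter), concerns a different place and gives no direct guide. Compound 2 also carries 4-fluorophenyl, but differs elsewhere too. A small move toward a higher number is therefore expected in this assay, probably near the scatter. The estimated step is a 1.4-fold higher number from compound 1 to compound 4 (0.15 log units; within the scatter) in size. For compound 4 the estimated value is 280 nM within an expected range of 110 nM to 700 nM in this assay.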

Compound 4, half-maximal inhibitory concentration: 620 nM
The estimate for compound 4 lay 2.2-fold (0.35 log units) below the measured number; measured number inside the range.
By their numbers in this assay, from the lowest: compound 1; then compound 4; then compounds 2 and 3 (each within the scatter of the next).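

In this assay the halogen on the 4-chlorophenyl ring of the ((4-chlorophenyl)sulfonyl)amino group is not interchangeable: fluoro in place of chloro gives a 3.1-fold higher number from compound 1 to compound 4 (0.49 log units; beyond the scatter). For the compounds shown here, this is the first measured step at this position, since the earlier step from the same parent concerned the 4-(trifluoromethyl)phenyl group elsewhere on the core. Nothing at hand accounts for the size of this step.

From the compounds shown here alone, a bromo, methoxy or amino group on this aromatic carbon remains open. So does whether the same exchange gives a similar step alongside the cyclohexyl group of compound 3.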